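A few compounds are considered here, and "the series" means these few. Any claim that something is new, unique, unknown or untested is made for them only; others in the source may bear on it.

Of the compounds shown here, three carrying the same saturated core have been measured in a functional assay on isolated protein for agonist activity at Glucose-dependent insulinotropic receptor (Homo sapiens), read by HTRF and cAMP accumulation; on this read-out higher numbers stand for an effect only at larger amounts of compound and lower numbers for an effect already at smaller amounts. Compound 1 `CC(C)(C)OC(=O)N1CCC(O[C@H]2CC[C@H](Oc3ccc(S(C)(=O)=O)c(F)c3)CC2)CC1` gives 52 nM, compound 2 `CC(C)(C)OC(=O)N1CCC(O[C@H]2CC[C@H](Oc3ccc(C#N)cc3)CC2)CC1` gives 8.6 nM, and compound 3 `CC(C)S(=O)(=O)c1cnc(O[C@H]2CC[C@H](OC3CCN(C(=O)OC(C)(C)C)CC3)CC2)cn1` gives 18.5 nM. Compound 2 thus stands lowest of the three in this assay, and its distance to both compound 3 and compound 1 lies beyond the usual scatter of such measurements. A fourth compound, compound 4 `CC(C)(C)OC(=O)N1CCC(O[C@H]2CC[C@H](Oc3ccc(S(C)(=O)=O)nn3)CC2)CC1`, has not yet been measured. It differs from compound 2 by 6-(methylsulfonyl)pyridazin-3-yl in place of 4-cyanophenyl on an oxygen on a saturated carbon. Among the compounds with values here, with no directly comparable pair among the measured compounds, the step from compound 2 to compound 4 in this assay is expected to be moderate and upward, near a 2.9-fold higher number from compound 2 to compound 4 (0.46 log units; beyond the scatter). For compound 4 the value in this assay is estimated at 25 nM, within a range from 8 nM to 80 nM.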

Compound 4, half-maximal effective concentration: 651 nM
For compound 4 the middle estimate is 26-fold (1.42 log units) below the measured one; the whole stated range lies below it.
By their numbers in this assay, from the lowest: compound 2; then compound 3; then compound 1; then compound 4.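

In this assay, the place on an oxygen on a saturated carbon does not accept every aromatic group: 6-(methylsulfonyl)pyridazin-3-yl in place of 4-cyanophenyl gives a 76-fold higher number from compound 2 to compound 4 (1.88 log units; beyond the scatter), a large step. Compound 1 also carries a methylsulfonyl group and gives 52 nM, so that group alone does not bring a number as high as that of compound 4. Nothing available gives a reason for this step.

The compounds shown leave open whether the ring or the methylsulfonyl group accounts for the step. A 6-cyanopyridazin-3-yl or a 4-(methylsulfonyl)phenyl group on the same oxygen would separate the two.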